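From Allyl to Benzyl on the Ring Nitrogen

The compounds below may be only part of what the source reports. "The series", "measured", "known", "first", "only" and "open" are said of these compounds alone.

compound 1 `C=CCN1C(=O)C(=O)c2cc(-c3ccc(OC)cc3)ccc21` — 7090 nM
compound 2 `COc1ccc(-c2ccc3c(c2)C(=O)C(=O)N3c2ccc(OC)cc2)cc1` — > 10000 nM, a limit of the assay
compound 3 `COc1ccc(-c2ccc3c(c2)C(=O)C(=O)N3Cc2ccc(Br)cc2)cc1` — 700 nM

In a functional assay on HepG2 cells (Homo sapiens) for antiproliferative activity, read by MTT assay, with a stated time of 48 h (a lower number here means a stronger inhibitor, a higher number a weaker inhibitor), compound 1 gives 7090 nM, the highest of the two numbers shown, while compound 3 gives 700 nM. For compound 2 the assay reports only a limit, > 10000 nM. Compound 4 `COc1ccc(-c2ccc3c(c2)C(=O)C(=O)N3Cc2cccc(OC)c2)cc1` has not yet been measured. It differs from compound 1 by 3-methoxyphenyl in place of vinyl on a saturated chain carbon bound to an amide-type nitrogen in a ring. The closest parallel among the measured steps is a 10-fold lower number from compound 1 to compound 3 (1.01 log units; beyond the scatter), also a move from allyl to a benzyl group; the other step, an at least 1.4-fold higher number from compound 1 to compound 2 (0.14 log units; that floor lies within the scatter), gave no lower number. The change to compound 4 is therefore expected to lower the number, a 4.7-fold lower number from compound 1 to compound 4 (0.67 log units; beyond the scatter). Compound 4 is estimated at 1500 nM, with a range from 500 nM to 5000 nM.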

Compound 4, half-maximal inhibitory concentration: 700 nM
Beside the measured number, compound 4's estimate is 2.1-fold (0.33 log units) above it; the measured number falls inside the stated range.
By their numbers in this assay, from the lowest: compounds 3 and 4 (each within the scatter of the next); then compound 1. At a limit, above all of these: compound 2.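

In this assay a second benzyl group repeats the drop seen with 4-bromobenzyl (a 10-fold lower number from compound 1 to compound 4 (1.01 log units; beyond the scatter)), so the drop from allyl is not confined to that one group. Exchanging 4-bromobenzyl for 3-methoxybenzyl gives no change at the digits printed from compound 3 to compound 4 (within the scatter) even though the two benzyl groups carry different substituents. A limit of the assay underlies an at least 14-fold lower number from compound 2 to compound 4 (1.15 log units; beyond the scatter) and that step is a floor only: the limit of > 10000 nM in this assay, at which 1 of the 4 values shown sits. The compounds shown leave open whether an unsubstituted benzyl group does as well, and whether a longer chain ending in an amine keeps the number this low.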